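Two close values, and a swap of the aryl group

The source may hold more compounds than are shown below. What is called first, only, known or untested is meant among the compounds shown, and "the series" means these compounds.

Compound 1 `CCN1CCC(n2cc(S(=O)(=O)c3cccc(F)c3)c3cccnc32)C1`, in an assay on HeLa cells for displacement of a labelled ligand from 5-hydroxytryptamine receptor 6 (Homo sapiens) (a lower number here means a stronger inhibitor, a higher number a weaker inhibitor), gives 8.3 nM.
Compound 2 `CN1CCCC(n2cc(S(=O)(=O)c3ccc(Cl)cc3)c3cccnc32)C1`, in this assay, gives 11.5 nM.

Both compounds share the same core, a sulfonyl group attached to it, and an aromatic ring on the sulfonyl sulfur; they differ in that aromatic ring and in the amine-bearing ring on the other side. Compound 2 has the higher of the two numbers, but its gap to compound 1 lies within the usual scatter of repeated measurements, so the two cannot be told apart on these numbers.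

Compound 3 `CN1CCCC(n2cc(S(=O)(=O)c3cccc(F)c3)c3cccnc32)C1` takes the amine-bearing ring of compound 2 and the aromatic ring of compound 1: 3-fluorophenyl in place of 4-chlorophenyl on a sulfonyl sulfur. For the measured compounds named here, no step between measured compounds covers this change alone, so the expectation rests on the fact that compound 1, which carries the same 3-fluorophenyl group, gives 8.3 nM, close to compound 2. A step of no more than the scatter is expected in either direction, a 1.3-fold lower number from compound 2 to compound 3 (0.11 log units; within the scatter). Compound 3 is therefore estimated at 9 nM, with a range from 4 nM to 20 nM.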

Compound 3, inhibition constant: 4.7 nM
Estimate against measurement, compound 3: 1.9-fold (0.28 log units) above; the measured number falls inside the stated range.
By their numbers in this assay, from the lowest: compounds 3, 1 and 2 (each within the scatter of the next, the first and the last beyond it).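

In this assay, with the 1-methylpiperidin-3-yl ring held fixed, 3-fluorophenyl in place of 4-chlorophenyl on a sulfonyl sulfur gives a 2.4-fold lower number from compound 2 to compound 3 (0.39 log units; beyond the scatter), so this single change to the aromatic ring is modest but can be told apart from measurement noise. The other single change, 1-methylpiperidin-3-yl in place of 1-ethylpyrrolidin-3-yl on an aromatic nitrogen, gives a 1.8-fold lower number from compound 1 to compound 3 (0.25 log units; within the scatter), so that pair cannot be told apart on these numbers. The data shown offer no explanation for either step.

The swap of the aromatic ring alters two things at once, the halogen and its ring position, so only compounds carrying 3-chlorophenyl or 4-fluorophenyl on the sulfonyl sulfur could show which of the two accounts for the step. From the compounds shown here alone, it also remains open whether the step would recur with a 1-ethylpyrrolidin-3-yl ring, and how an unsubstituted phenyl or a 3-methoxyphenyl group would compare at this sulfur.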